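Notes on the aryl group at the triazole carbon

This account rests on a few compounds, and the source may have more. Where it says the series, first, only, none or still open, it means among the compounds named here.

In an assay on isolated protein for inhibition of somatostatin receptor type 2 (Homo sapiens), tested at 10 uM (on this read-out higher numbers stand for weaker inhibition and lower numbers for stronger inhibition), the three measured compounds span a wide range. Compound 1 `NCCCCn1c(SCCc2c[nH]c3ccccc23)nnc1-c1cnc2ccccc2n1` gives 32 nM; compound 2 `NCCCCn1c(SCCc2c[nH]c3cc(F)ccc23)nnc1-c1ccc2ccccc2n1` gives 2.7 nM; compound 3 `NCCCCn1c(SCCc2c[nH]c3ccccc23)nnc1-c1cc2ccccc2s1` gives 160 nM. Compound 3 thus stands at the highest number of the three, with compound 1 nearest and compound 2 furthest, both steps beyond the scatter.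

Going by the values given here, the one single-point step known is a 5.0-fold higher number from compound 1 to compound 3 (0.70 log units; beyond the scatter), so the exchange of the group on this aromatic carbon has already moved this assay by a modest but clear amount.

Compound 4 `CCc1ccc(-c2nnc(SCCc3c[nH]c4ccccc34)n2CCCCN)cc1` continues that exchange: 4-ethylphenyl in place of 1-benzothiophen-2-yl on an aromatic carbon. Among the compounds with values here, no measured pair covers 4-ethylphenyl at this position, and compounds 1 and 2 differ from each other in more than one place, so nothing directly predicts the direction. With a shown step of modest size for a related exchange, a step of similar size or smaller is expected here, most likely toward a higher number.

Compound 4 is therefore estimated at 250 nM, a step of a 1.6-fold higher number from compound 3 to compound 4 (0.19 log units; within the scatter), within a range of 70 nM to 900 nM.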

Compound 4, inhibition constant: 430 nM
Beside the measured number, compound 4's estimate is 1.7-fold (0.24 log units) below it, and the stated range covers the measured number.
By their numbers in this assay, from the lowest: compound 2; then compound 1; then compound 3; then compound 4.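

In this assay, 4-ethylphenyl in place of 1-benzothiophen-2-yl gives a 2.7-fold higher number from compound 3 to compound 4 (0.43 log units; beyond the scatter), so this position still responds when one aromatic ring of carbon only enters in place of a group with two aromatic rings. Against quinoxalin-2-yl, the same group gives a 13-fold higher number from compound 1 to compound 4 (1.13 log units; beyond the scatter), and among compounds 1, 3 and 4, which differ only here, both groups with two aromatic rings give lower numbers than 4-ethylphenyl, with no exception. Nothing shown explains this order.

Steps involving compound 2 cannot be read, as it differs from the others in more than one place. Open, from the compounds shown here alone, is whether an amine or a carboxylic acid in place of the ethyl group on the phenyl ring would keep the number near that of compound 4 or move it toward that of compound 1.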